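This account rests on a few compounds, and the source may have more. Where it says the series, first, only, none or still open, it means among the compounds named here.

Measured in a functional assay on C6 cells (Rattus norvegicus) for cytotoxicity, read by MTT assay, with a stated time of 24 h, tested at 100 ug/mL; on this read-out lower numbers stand for a stronger effect and higher numbers for a weaker effect at the one concentration tested:
- compound 1 `Cc1nnc(SCC(=O)N/N=c2/scc(-c3ccccc3)n2-c2ccccc2)s1`: 61.8%
- compound 2 `Cn1cnnc1SCC(=O)N/N=c1/scc(-c2ccc(C#N)cc2)n1-c1ccccc1`: 55.2%

Two compounds have been run so far in this assay. Compound 2 gives 55.2%, and compound 1 gives 61.8%; the gap between these two numbers lies within the usual scatter, so no difference between compound 1 and compound 2 can be claimed from them. Among the measured compounds shown here, no pair of measured compounds differing in a single place is available, so no step size is known from the series itself.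

Compound 3 `Cn1cnnc1SCC(=O)N/N=c1/scc(-c2ccccc2)n1-c1ccccc1` is the next candidate. It differs from compound 2 in one place:

hydrogen in place of cyano on an aromatic carbon

For the measured compounds named here, with no measured step to lean on, the expectation for compound 3 in this assay is a step from compound 2 of no more than the scatter, in no particular direction, because compound 2 gives 55.2% and compound 1, which also carries a phenyl at that position, gives 61.8%. Compound 3 is therefore expected to give about 59% in this assay, with a likely range from 45% to 73%. The step implied, a number 3.8 percentage points higher from compound 2 to compound 3 (within the scatter), is an estimate only.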

Compound 3, a percentage reported as activity, at one concentration (the size of the read-out at that concentration, not a potency): 38.6%
The estimate for compound 3 lay 20.4 percentage points above the measured number, outside the stated range (below it).
By their numbers in this assay, from the lowest: compound 3; then compounds 2 and 1 (each within the scatter of the next).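

Each of the two single changes now has a measured effect in this assay. Going from 4-cyanophenyl to phenyl gives a number 16.6 percentage points lower from compound 2 to compound 3 (beyond the scatter), so this position is sensitive to substitution and the cyano group is not needed for the effect at the one concentration tested. Placing 4-methyl-4H-1,2,4-triazol-3-yl instead of 5-methyl-1,3,4-thiadiazol-2-yl on the sulfur gives a number 23.2 percentage points lower from compound 1 to compound 3 (beyond the scatter), which makes compound 3 the strongest of the series on this read-out, though nothing available accounts for either step.

Still open, from the compounds shown here alone, is whether an amine or a methoxy group at the position held by cyano in compound 2 would read closer to the cyano or the hydrogen result. Also open, going by these compounds, is whether the cyano step holds with the 5-methyl-1,3,4-thiadiazol-2-yl group on the sulfur.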